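A few compounds are considered here, and "the series" means these few. Any claim that something is new, unique, unknown or untested is made for them only; others in the source may bear on it.

Compounds measured so far:
- compound 1 `C=C1C(=O)[C@]23C[C@@]1(O)CC[C@H]2c1ccc(OS(=O)(=O)c2ccc(C)cc2)c(C)c1[C@@H]3Cn1cc(-c2ccccn2)nn1`; in a functional assay on MCF7 cells (Homo sapiens) for cytotoxicity, read by MTT assay, with a stated time of 4 days (a higher number here means a weaker inhibitor, a lower number a stronger inhibitor), compound 1 gives 320 nM
- compound 2 `C=C1C[C@]23C[C@@]1(O)CC[C@H]2c1ccc(OS(=O)(=O)c2ccc(C)cc2)c(C)c1[C@@H]3Cn1cc(-c2ccc(OC)cc2)nn1`; in this assay compound 2 gives > 20000 nM, which is a limit of the assay and not a number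
- compound 3 `C=C1C(=O)[C@]23C[C@@]1(O)CC[C@H]2c1ccc(O)c(C)c1[C@@H]3Cn1cc(-c2ccccn2)nn1`; in this assay compound 3 gives 2240 nM

Within the data shown here, compound 3 holds the higher of the two numbers available; the only measured single-point step, a 7.0-fold higher number from compound 1 to compound 3 (0.85 log units; beyond the scatter), shows that the hydroxyl analogue is the weaker of that pair, well beyond the scatter. Among the measured compounds shown here, compound 2 is the only compound carrying the 4-methoxyphenyl group, and in this assay it reaches only the limit (the limit of > 20000 nM in this assay, at which 1 of the 3 values shown sits); it differs from compound 1 in two places at once, so its value bears on the present change only loosely.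

Compound 4 `C=C1C(=O)[C@]23C[C@@]1(O)CC[C@H]2c1ccc(O)c(C)c1[C@@H]3Cn1cc(-c2ccc(OC)cc2)nn1` is compound 3 with 4-methoxyphenyl in place of pyridin-2-yl on an aromatic carbon. For the measured compounds named here, no measured step covers this exchange alone. Given that compound 2, which also bears the 4-methoxyphenyl group, sits at the limit of > 20000 nM in this assay, at which 1 of the 3 values shown sits, a move toward weaker inhibition is expected, and the step from compound 3 to compound 4 is estimated at a 4.5-fold higher number from compound 3 to compound 4 (0.65 log units; beyond the scatter). For compound 4 the expected value in this assay is 10000 nM, with a range from 3000 nM to 30000 nM.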

Compound 4, half-maximal inhibitory concentration: 1710 nM
Beside the measured number, compound 4's estimate is 5.8-fold (0.77 log units) above it; the whole stated range lies above it.
By their numbers in this assay, from the lowest: compound 1; then compounds 4 and 3 (each within the scatter of the next). At a limit, above all of these: compound 2.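

On an aromatic carbon of the five-membered aromatic ring with 3 nitrogen, with the free hydroxyl in place, pyridin-2-yl and 4-methoxyphenyl cannot be told apart in this assay: the exchange gives a 1.3-fold lower number from compound 3 to compound 4 (0.12 log units; within the scatter). Among these compounds, the 4-methoxyphenyl group alone therefore does not carry a loss at this position in this pair, a point the earlier compounds could not show. Compound 2 remains a limit of the assay and not a number, and its two differences from compound 1 stay unseparated: the limit of > 20000 nM in this assay, at which 1 of the 4 values shown sits.

Open, from the compounds shown here alone, is whether the same exchange stays as flat when the (4-methylphenyl)sulfonyl group sits on the oxygen, and what the carbonyl contributes by itself. Also open, going by these compounds, is whether a carboxylic acid or an amine on this carbon would move the number beyond the scatter.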